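Imidazolyl to pyrazolyl swap on the methoxyphenyl core

This account rests on a few compounds, and the source may have more. Where it says the series, first, only, none or still open, it means among the compounds named here.

Of the compounds shown here, three have been measured in an ADME assay on microsomes from liver (Rattus norvegicus) for metabolic stability, read by LC-MS; on this read-out lower numbers stand for slow clearance and higher numbers for fast clearance. Compound 1 `COc1cc(N2CCN(C(=O)Cn3cnc4cccc(C(F)(F)F)c43)CC2)ccc1-c1cnc(C)o1` gives 7 mL.min-1.g-1. Compound 3 `COc1cc(N2CCN(C(=O)Cn3ncc4ccccc43)CC2)ccc1-c1cnc(C)o1` gives 77 mL.min-1.g-1. Compound 2 `COc1cc(N2CCN(C(=O)N[C@@H](C)c3cccc4ccccc34)CC2)ccc1-n1cnc(C)c1` gives 150 mL.min-1.g-1. Compound 2 and compound 3 give numbers within the scatter of each other, so nothing about their order can be said; compound 1 sits beyond the scatter below both of them. Within the data shown here, no pair among the three differs in a single place, so no single structural step can be read from the measured numbers.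

Compound 4 `COc1cc(N2CCN(C(=O)N[C@@H](C)c3cccc4ccccc34)CC2)ccc1-c1cnn(C)c1` has not been measured. It differs from compound 2 in one place: 1-methyl-1H-pyrazol-4-yl in place of 4-methyl-1H-imidazol-1-yl on an aromatic carbon. The two compounds have the same atoms, joined differently, and the rest of the shared core is untouched. Nothing in the series shows what this rearrangement does in this assay, so the expectation can rest only on the number for compound 2.

The step of a 1.3-fold lower number from compound 2 to compound 4 (0.10 log units; within the scatter) is expected to stay within the scatter, with no direction preferred. Compound 4 is estimated at 120 mL.min-1.g-1, with a range from 45 mL.min-1.g-1 to 320 mL.min-1.g-1, the width reflecting the absence of any measured step of this kind.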

Compound 4, intrinsic clearance in microsomes: 150 mL.min-1.g-1
Compound 4: the middle estimate sits 1.3-fold (0.10 log units) below what was measured; the range from low to high includes it.
By their numbers in this assay, from the lowest: compound 1; then compounds 3, 2 and 4 (each within the scatter of the next).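

In this assay, among these compounds, the replacement of 4-methyl-1H-imidazol-1-yl by 1-methyl-1H-pyrazol-4-yl gives no change at the digits printed from compound 2 to compound 4 (within the scatter) and is the only one-place step available so far. The earlier compounds shown here could say nothing about this place, on an aromatic carbon ortho to a methoxy group and para to a large group; this pair shows that, with the rest of compound 2 held constant, joining the same atoms differently leaves the clearance read-out unmoved. Nothing measured bears on what lies behind this outcome.

Still open, on these data alone, is whether a group of a different kind at this place, such as a nitrile or a primary amine, would move the read-out beyond the scatter, since both groups compared here are methyl-bearing five-membered aromatic rings with the same atom count. Among the compounds shown here, also open is whether the same exchange would read alike with the other end of compound 1 or compound 3 in place of the one carried by compound 2, as the single step rests on one background only.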